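Working notes: from compound 2 to compound 3

The source may report more compounds than this note shows. Statements on the series, on what has been measured and on what is new or still open speak of the compounds shown alone.

In a functional assay on AGS cells (Homo sapiens) for inhibition, read by MTT assay, with a stated time of 72 h (a higher number here means a weaker inhibitor, a lower number a stronger inhibitor), compound 1 `CC(C)=CCC/C(C)=C/C[C@@H]1C[C@]2(CC=C(C)C)C(=O)[C@@](CC=C(C)C)(C(=O)C(C(=O)c3ccc(O)c(OC(=O)CCCC[C@@H]4SCC5NC(=O)NC54)c3)=C2O)[C@@]1(C)CCC=C(C)C` gives 12200 nM and compound 2 `CC(C)=CCC/C(C)=C/C[C@@H]1C[C@]2(CC=C(C)C)C(=O)[C@@](CC=C(C)C)(C(=O)C(OC(=O)c3ccc(O)c(O)c3)=C2O)[C@@]1(C)CCC=C(C)C` gives 10200 nM. Among the compounds with values here, compound 2 therefore stands within the scatter of the only other value, and the two numbers cannot be ranked.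

Compound 3 `CC(C)=CCC/C(C)=C/C[C@@H]1C[C@]2(CC=C(C)C)C(=O)[C@@](CC=C(C)C)(C(=O)C(Cc3ccc(O)c(O)c3)=C2O)[C@@]1(C)CCC=C(C)C` carries 3,4-dihydroxybenzyl in place of ((3,4-dihydroxyphenyl)carbonyl)oxy on a double-bonded ring carbon, next to the ring atom that bears a hydroxy group (3,4-dihydroxybenzyl in place of ((3,4-dihydroxyphenyl)carbonyl)oxy on a double-bonded ring carbon). The shared core is otherwise unchanged.

Within the data shown here, the series holds no measured single-place step, so the size of this change has no direct precedent. The step of a 1.1-fold lower number from compound 2 to compound 3 (0.05 log units; within the scatter) is expected to stay within the scatter, with no firm direction. The estimated value for compound 3 is 9000 nM, with an expected range of 4000 nM to 20000 nM.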

Compound 3, half-maximal inhibitory concentration: > 20000 nM
Compound 3 gave a limit, no number (the forecaster's own chance of this, stated with the estimate: 5%); middle value at least 2.2-fold (0.34 log units) from the limit.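

Within the data shown here, the step at this double-bonded ring carbon is the first single-place comparison: with 3,4-dihydroxybenzyl in place of ((3,4-dihydroxyphenyl)carbonyl)oxy, this assay gives an at least 1.9-fold higher number from compound 2 to compound 3 (0.29 log units; that floor lies within the scatter). The result for compound 3 is a limit, not a number: the limit of > 20000 nM in this assay, at which 1 of the 3 values shown sits. The change therefore gives no lower number at this position, although the floor of the step does not establish a real loss, and the retained 3,4-dihydroxyphenyl ring alone does not secure a reading like that of compound 2.

On these data alone, the true size of the step remains open, as does whether the carbonyl or the oxygen link of the departing group matters more. Also open, as far as these compounds go, is how an amine or a carboxylic acid on this ring carbon would read in this assay.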